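The source may report more compounds than this note shows. Statements on the series, on what has been measured and on what is new or still open speak of the compounds shown alone.

Values in a physicochemical assay for lipophilicity, read by HPLC, in phosphate buffer, measured as chromatographic lipophilicity, at pH 7.4; a higher number here means a more lipophilic compound, a lower number a more polar compound:
compound 1 `COc1ccc2nc(C)cc(OCC(=O)Nc3cc(C)cc(C)c3)c2c1`: 5.64
compound 2 `COc1ccc2nc(C)cc(OCC(=O)Nc3cccc(C)c3)c2c1`: 4.83
compound 3 `COc1ccc2nc(C)cc(OCC(=O)Nc3ccc(Cl)c(OC)c3)c2c1`: 5.09

In this assay compound 3 stands second highest of the three measured numbers: a number 0.26 log units higher from compound 2 to compound 3 (within the scatter), whereas a number 0.55 log units lower from compound 1 to compound 3 (beyond the scatter). Compound 4 `COc1ccc2nc(C)cc(OCC(=O)Nc3ccc(Cl)cc3)c2c1` differs from compound 3 by hydrogen in place of methoxy on an aromatic carbon. Among the measured compounds shown here, no measured step removes a methoxy; the only step that trades a ring substituent for hydrogen is a number 0.81 log units lower from compound 1 to compound 2 (beyond the scatter), and that concerns a methyl, not a methoxy, so it transfers only loosely. The swaps of the whole aryl on the amide nitrogen, a number 0.26 log units higher from compound 2 to compound 3 (within the scatter) and a number 0.55 log units lower from compound 1 to compound 3 (beyond the scatter), mix several changes at once. The expected step for compound 4 is therefore small, a number 0.16 log units higher from compound 3 to compound 4 (within the scatter), not beyond the scatter. Compound 4 is estimated at 5.25, with a range of 4.85 to 5.65.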

Compound 4, distribution coefficient: 5.15
For compound 4 the middle estimate is 0.10 log units above the measured one; measured number inside the range.
By their numbers in this assay, from the lowest: compounds 2, 3 and 4 (each within the scatter of the next, the first and the last beyond it); then compound 1.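

In this assay, trading methoxy for hydrogen on an aromatic carbon ortho to a chloro group gives a step that cannot be told from the scatter: a number 0.06 log units higher from compound 3 to compound 4 (within the scatter). The 4-chlorophenyl group separates from both methyl-bearing aryl groups on the amide-type nitrogen, with a number 0.32 log units higher from compound 2 to compound 4 (beyond the scatter) and a number 0.49 log units lower from compound 1 to compound 4 (beyond the scatter), whereas compound 3 did not separate from compound 2. Nothing available explains these numbers.

As far as these compounds go, whether an amine, a carboxylic acid or a longer alkoxy chain at this position would also stay within the scatter remains open. So does the methoxy-to-hydrogen step on a ring without the chloro group.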